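Benzyl-bearing analogues and a chloro replacement at the shared core

A few compounds are considered here, and "the series" means these few. Any claim that something is new, unique, unknown or untested is made for them only; others in the source may bear on it.

Of the compounds shown here, three have been measured in a functional assay on EL4 cells (Mus musculus) for inhibition, tested at 100 uM; a higher number here means more inhibition at the concentration tested (going by the name of the read-out), a lower number less inhibition. Compound 1 `OC[C@H]1OC(n2cnc3c(NCc4ccccc4)nccc32)[C@H](O)[C@@H]1O` carries a benzylamino group on the shared core and gives 5%. Compound 2 `OC[C@H]1OC(n2cnc3c(S)nccc32)[C@H](O)[C@@H]1O` carries a sulfanyl group there; its result in this assay is a limit and not a number, < 5%, one of the values that sit at the limit of < 5% in this assay, at which 1 of the 3 values shown sits. Compound 3 `OC[C@H]1OC(n2cnc3c(SCc4ccccc4)nccc32)[C@H](O)[C@@H]1O` carries a benzylsulfanyl group and gives 30%, the highest of the two numbers shown, with compound 1 nearest to it.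

The measured steps are small in number but consistent in direction. Exchanging the group on the aromatic carbon gives a number 25 percentage points higher from compound 1 to compound 3 (beyond the scatter). Adding the benzyl to the sulfur gives a number at least 25 percentage points higher from compound 2 to compound 3 (beyond the scatter). Between the two benzyl-free compounds the change is a number no higher from compound 1 to compound 2 (the limit leaves the size open).

Compound 4 `OC[C@H]1OC(n2cnc3c(Cl)nccc32)[C@H](O)[C@@H]1O` is not yet measured. It differs from compound 3 as follows: chloro in place of benzylsulfanyl on an aromatic carbon. The step from compound 2 to compound 3 is the one that bears most on this change, since it shows what the benzyl on the sulfur contributes; compound 4 loses the whole benzylsulfanyl group. A drop in this assay is therefore expected, of about a number 22 percentage points lower from compound 3 to compound 4 (beyond the scatter), back toward the values of compound 1 and compound 2. Compound 4 is thus expected to give 8%, between 0% and 20%, with a fair chance that only a limit is reported.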

Compound 4, a percentage reported as inhibition, at one concentration (the size of the read-out at that concentration, not a potency): < 5%
Compound 4 was reported as a limit; the forecaster's own chance of this, stated with the estimate: 40%; middle value at least 3 percentage points from the limit.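

The chloro compound shows that the benzylsulfanyl group can be exchanged for a single atom on this aromatic carbon next to the ring nitrogen only at a clear cost in this assay: the change gives a number at least 25 percentage points lower from compound 3 to compound 4 (beyond the scatter). Going by these compounds alone, the earlier drop was seen only on removing the benzyl from the sulfur, whereas this one comes with a replacement that has no sulfur and no ring, so the result no longer rests on the sulfanyl comparison alone. Compound 4 gives < 5%, which is a limit and not a number, and the series now has a second compound at this floor: the limit of < 5% in this assay, at which 2 of the 4 values shown sit.

Chloro in place of benzylamino gives a number no higher from compound 1 to compound 4 (the limit leaves the size open), while the step between compound 2 and compound 4 cannot be read, since both results are limits. Still open, going by these compounds, is whether the read-out of compound 3 depends on the sulfur link and the benzyl together, which benzyloxy, phenethylsulfanyl or methylsulfanyl at this position would test, and whether a methoxy or chloro substituent on the benzyl ring would move the value.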